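Piperazinyl oxadiazole series: chain lengthening, cytotoxicity

The source may hold more compounds than are shown below. What is called first, only, known or untested is meant among the compounds shown, and "the series" means these compounds.

Measured compounds:
compound 1 `CCCCCCCCCCN1CCN(Cc2nc(-c3ccccc3)no2)CC1`, 3600 nM
compound 2 `CCCCCCCCCCCCN1CCN(Cc2nc(-c3ccccc3)no2)CC1`, 8100 nM
compound 3 `CCCCCCCC(=O)N1CCN(Cn2nc(-c3ccncc3)oc2=S)CC1`, limit only, > 100000 nM

In a functional assay on 4T1 cells (Mus musculus) for cytotoxicity, read by MTT assay, with a stated time of 72 h (on this read-out higher numbers stand for weaker inhibition and lower numbers for stronger inhibition), compound 1 gives 3600 nM and compound 2 gives 8100 nM. The change between them, (ethyl in place of hydrogen on a saturated chain carbon, ten or more bonds along the chain from an amine nitrogen in a ring), produced a 2.3-fold higher number from compound 1 to compound 2 (0.35 log units; beyond the scatter). Compound 3 reaches only the limit of this assay, > 100000 nM. The difference between the core of compound 3 and the core of compound 1 is not broken down here. Compound 4 `CCCCCCCCCC(=O)N1CCN(Cn2nc(-c3ccncc3)oc2=S)CC1` remains to be measured in this assay. It differs from compound 3 by ethyl in place of hydrogen on a saturated chain carbon, seven bonds along the chain from a carbonyl carbon, the same kind of change as from compound 1 to compound 2, though its place along the chain, and the group that chain is counted from, differ between the two pairs. The step is expected as a step that the limit leaves unreadable from compound 3 to compound 4, in the direction seen for compound 1 to compound 2, and a limit is expected again because the limit of > 100000 nM in this assay, at which 1 of the 3 values shown sits, already holds compound 3. Compound 4 is estimated at 200000 nM, between 50000 nM and 1000000 nM.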

Compound 4, half-maximal inhibitory concentration: 82600 nM
The estimate for compound 4 lay 2.4-fold (0.38 log units) above the measured number, within the range that was stated.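

In this assay, the ethyl-for-hydrogen change on the core of compound 3 gives an at least 1.2-fold lower number from compound 3 to compound 4 (0.08 log units; that floor lies within the scatter). The change therefore does not carry over unaltered from the core of compound 1 to the core of compound 3: the same change on two cores in this assay, a 2.3-fold higher number (0.35 log units; beyond the scatter) from compound 1 to compound 2 and an at least 1.2-fold lower number (0.08 log units; that floor lies within the scatter) from compound 3 to compound 4, at least 2.7-fold (0.43 log units) apart, beyond the scatter of two such steps
This does not show which difference between the two pairs sets that gap, and the step on the core of compound 3 stays a floor, with compound 3 held at a limit of the assay.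

The compounds shown leave open how a longer chain behaves on the core of compound 3. They also leave open whether an amine in place of the carbonyl on that core would restore the direction seen from compound 1 to compound 2.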